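A few compounds are considered here, and "the series" means these few. Any claim that something is new, unique, unknown or untested is made for them only; others in the source may bear on it.

Measured so far in a functional assay on the whole organism for activation, with Mus musculus as the target, with a stated time of 60 min; a higher number here means that more compound is needed for the effect, a lower number that less compound is needed:
- compound 1 `O=C1NC(=O)N(/N=C/c2ccc(-c3ccc(Cl)c(Cl)c3)o2)C1O` gives 72 mg/kg as its half-maximal dose
- compound 2 `N#Cc1ccc(-c2ccc(/C=N/N3C(=O)NC(=O)C3O)o2)cc1` gives 156 mg/kg as its half-maximal dose
- compound 3 `O=C1CN(/N=C/c2ccc(-c3cccc(C(F)(F)F)c3)o2)C(=O)N1` gives 143 mg/kg as its half-maximal dose

Compound 2 (156 mg/kg) and compound 3 (143 mg/kg) lie within the scatter of each other. Compound 1 (72 mg/kg) shows a lower number than compound 2, and that gap lies beyond the scatter.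

Compound 4 (`Nc1ccc(-c2ccc(/C=N/N3C(=O)NC(=O)C3O)o2)cc1`) has not yet been measured. It keeps the core of compound 2 and carries amino in place of cyano on an aromatic carbon, para to a large group (amino in place of cyano on an aromatic carbon). Among the compounds with values here, no measured pair of compounds shows this change on its own, so the expectation in this assay is a loose one and rests on the narrow spread of the three numbers. No step beyond the scatter is expected, and the estimated 1.3-fold lower number from compound 2 to compound 4 (0.11 log units; within the scatter) leans only slightly towards a lower number. Within the data shown here, that lean follows compound 1 (72 mg/kg), the one measured compound clearly apart from compound 2. For compound 4 the estimated value is 120 mg/kg, with 55 mg/kg to 260 mg/kg as the expected range.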

Compound 4, dose for half-maximal effect: > 1000 mg/kg
Compound 4: only a limit was reported; the forecaster's own chance of this, stated with the estimate: 10%; middle value at least 8.3-fold (0.92 log units) from the limit.
By their numbers in this assay, from the lowest: compounds 1, 3 and 2 (each within the scatter of the next, the first and the last beyond it). At a limit, above all of these: compound 4.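

In this assay, the change from cyano to amino on an aromatic carbon, para to a large group, gives an at least 6.4-fold higher number from compound 2 to compound 4 (0.80 log units; beyond the scatter). This is the first change in a single place among the compounds shown, and it reveals what the three earlier numbers could not: the group at this position can move the half-maximal dose well beyond the scatter, so this position is not indifferent to what it carries. The entry for compound 4 is a limit of the assay and not a number: the limit of > 1000 mg/kg in this assay, at which 1 of the 4 values shown sits.

Going by these compounds, how far the true value of compound 4 lies from that limit remains open, so the step has a floor but no known size, and a single pair cannot separate the loss of cyano from the arrival of amino. Also open, on these data alone, is what other groups at this position would give, such as a carboxylic acid, a methoxy group or a hydroxyl group, and whether amino would have a similar effect on a differently substituted version of the core.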